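This account rests on a few compounds, and the source may have more. Where it says the series, first, only, none or still open, it means among the compounds named here.

Measured so far:
compound 1 `CCc1ccc2[nH]c(=O)c(CN(Cc3cccc(F)c3)Cc3ccc4ccccc4c3)cc2c1` — in a toxicity assay on MDCK cells (Canis lupus familiaris) for cytotoxicity, read by crystal violet staining, with a stated time of 48 h (on this read-out lower numbers stand for higher toxicity in this test and higher numbers for lower toxicity in this test), compound 1 gives > 5000 nM, a limit of the assay.
compound 2 `Cc1ccc2[nH]c(=O)c(CN(Cc3ccc(OCC(=O)O)cc3)Cc3ccc(C(C)(C)C)cc3)cc2c1` — in this assay compound 2 gives > 10000 nM, a limit of the assay.

Within the data shown here, neither value is a number; both sit at a limit (the limit of > 10000 nM in this assay, at which 1 of the 2 values shown sits, (the limit of > 5000 nM in this assay, at which 1 of the 2 values shown sits)), so no step between them can be read and nothing is known about their order. Compound 2 therefore stands only at the upper limit of the measured range in this assay, with no toxicity seen up to that concentration.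

Compound 3 `Cc1ccc2[nH]c(=O)c(CN(Cc3ccc(OCCO)cc3)Cc3ccc(C(C)(C)C)cc3)cc2c1` differs from compound 2 in one place: hydroxymethyl in place of carboxy on a saturated chain carbon bound to an oxygen on an aromatic ring. Among the measured compounds shown here, no measured pair covers such a change, so the direction is open; with compound 2 already at a limit, the step from compound 2 to compound 3 is expected to stay within the scatter, at about a number no higher from compound 2 to compound 3 (the limit leaves the size open). Compound 3 is accordingly expected to give roughly 10000 nM in this assay, within 4000 nM to 30000 nM, most likely again reported only as a limit.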

Compound 3, half-maximal cytotoxic concentration: > 5000 nM
Compound 3: a limit, no number; the forecaster's own chance of this, stated with the estimate: 70%; the middle value is on the limit's open side.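

In this assay compound 2 gives > 10000 nM, a limit. Compound 3 gives > 5000 nM, also a limit. No step can be read between these two compounds. The compounds shown leave open at what concentration, if any, compound 1, compound 2 or compound 3 becomes toxic, and whether hydroxymethyl in place of carboxy changes that.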